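Mirror-image of a sulfur-linked ring compound in mice

A few compounds are considered here, and "the series" means these few. Any claim that something is new, unique, unknown or untested is made for them only; others in the source may bear on it.

Measured compounds:
- compound 1, `CCCCSc1nsnc1[C@@H]1CN2CCC[C@H]1C2`: > 3 mg/kg in a functional assay on the whole organism with Mus musculus as the target; on this read-out higher numbers stand for an effect only at larger amounts of compound and lower numbers for an effect already at smaller amounts
- compound 2, `CCCSc1nsnc1[C@H]1CN2CCC[C@@H]1C2`: > 3 mg/kg in this assay

Compound 1 gives only a limit in this assay, > 3 mg/kg. Compound 2 likewise reaches only a limit, > 3 mg/kg, so no number is known for it. Where compound 2 stands can therefore only be told in terms of that boundary: it sits at the limit of > 3 mg/kg in this assay, at which 2 of the 2 values shown sit, together with every other value shown.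

The step goes from compound 2 to compound 3, `CCCSc1nsnc1[C@@H]1CN2CCC[C@H]1C2`. Here (the two compounds have the same atoms and bonds; at least one stereo element is drawn with a configuration in one of them and without one in the other: 2 of 3 stereo elements differ; a stereocentre at a saturated ring carbon is drawn R in compound 2 and S in compound 3; a stereocentre at a saturated ring carbon is drawn S in compound 2 and R in compound 3). In other words the two compounds have the same atoms and bonds; at least one stereo element is drawn with a configuration in one of them and without one in the other, and a stereocentre at a saturated ring carbon that is drawn R in compound 2 is S in compound 3, while a stereocentre at a saturated ring carbon drawn S in compound 2 is R in compound 3.

Within the data shown here, no measured pair with such a change exists here, so the size of the step in this assay cannot be read off. Compound 1, which carries the same drawn configurations as compound 3, also sits at the limit, so the expectation is a step of no clear size beyond the scatter, a step that the limit leaves unreadable from compound 2 to compound 3, most likely ending again at a limit. Compound 3 is expected to give about 5 mg/kg, within 1 mg/kg to 30 mg/kg.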

Compound 3, dose for half-maximal effect: > 3 mg/kg
Compound 3 gave a limit, no number (the forecaster's own chance of this, stated with the estimate: 70%); the middle value is on the limit's open side.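

Compound 3, like compound 2 and compound 1, gives only a limit in this assay and no number, so no new step can be read from compound 2 or compound 1 to compound 3. The compounds shown leave open whether the swapped configuration or the change in chain length alters the dose for half-maximal effect at all.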